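This account rests on a few compounds, and the source may have more. Where it says the series, first, only, none or still open, it means among the compounds named here.

Measured so far:
compound 1, `COc1cc(-c2nn(-c3ccc(NC(=O)Nc4ccc(Cl)c(C(F)(F)F)c4)cc3)cc2-c2ccncc2)ccc1Cl`: 1600 nM
compound 2, `COc1cc(-c2nn(-c3ccc(NC(=O)c4cc(Cl)cc(Cl)c4)cc3)cc2-c2ccncc2)ccc1Cl`: > 100000 nM

Two compounds share one core and differ in the group joined to the amide-type nitrogen. In a functional assay on MDA-MB-435 cells (Homo sapiens) for antiproliferative activity, read by sulforhodamine B assay, with a stated time of 48 h (on this read-out lower numbers stand for stronger inhibition and higher numbers for weaker inhibition), compound 1 gives 1600 nM. Compound 2 gives only a limit of the assay in this assay, > 100000 nM, so its true number is not known, and it sits at the limit of > 100000 nM in this assay, at which 1 of the 2 values shown sits. Among the compounds with values here, the one measured step, an at least 62-fold higher number from compound 1 to compound 2 (1.79 log units; beyond the scatter), changes both the link and the ring at once, so it cannot separate the two changes.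

Compound 3, `COc1cc(-c2nn(-c3ccc(NC(=O)c4ccc(Cl)c(C(F)(F)F)c4)cc3)cc2-c2ccncc2)ccc1Cl`, is not yet measured. Compared with compound 2 it carries 4-chloro-3-(trifluoromethyl)phenyl in place of 3,5-dichlorophenyl on a carbonyl carbon. This returns the ring of compound 1 while keeping the carbonyl link of compound 2, so only part of the measured step is undone. The bearing step is an at least 62-fold higher number from compound 1 to compound 2 (1.79 log units; beyond the scatter), which was large; how much of it belongs to the ring is open. A move in this assay toward lower numbers is expected for compound 3, but with wide uncertainty: the estimated step is an at least 5.0-fold lower number from compound 2 to compound 3 (0.69 log units; beyond the scatter), and compound 3 is expected near 20000 nM, between 3000 nM and 150000 nM.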

Compound 3, half-maximal inhibitory concentration: 2520 nM
Compound 3: the middle estimate sits 7.9-fold (0.90 log units) above what was measured; measured number below the stated range.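

In this assay, this change shows that the ring on the carbonyl carbon can matter a great deal: with the carbonyl link kept, 4-chloro-3-(trifluoromethyl)phenyl in place of 3,5-dichlorophenyl gives an at least 39-fold lower number from compound 2 to compound 3 (1.59 log units; beyond the scatter). The link, by contrast, makes no readable difference with this ring: 4-chloro-3-(trifluoromethyl)phenyl in place of (4-chloro-3-(trifluoromethyl)phenyl)amino gives a 1.6-fold higher number from compound 1 to compound 3 (0.20 log units; within the scatter), so the large earlier step between compound 1 and compound 2 now traces to the ring rather than to the loss of the amino nitrogen. On these data alone, the true size of the ring step remains unknown, since compound 2 has a limit and not a number: the limit of > 100000 nM in this assay, at which 1 of the 3 values shown sits.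

The two rings differ in more than one substituent, so the compounds shown cannot tell whether the trifluoromethyl group or the arrangement of the chlorine atoms carries the step, and a ring with a nitrile in place of trifluoromethyl would be a further open case. As far as these compounds go, whether the amino and carbonyl links also match on the 3,5-dichlorophenyl ring remains open as well, since the link comparison rests on a single ring.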